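A Chain Swap Beside the Hydroxy Amide

The source may report more compounds than this note shows. Statements on the series, on what has been measured and on what is new or still open speak of the compounds shown alone.

compound 1 `COC(C)(C)[C@@H](O)C(=O)N1N=CC[C@H]1C(=O)NCc1cc(Cl)ccc1-n1cnnn1`: < 12 mL.min-1.g-1
compound 2 `O=C(NCc1cc(Cl)ccc1-n1cnnn1)[C@@H]1CCON1C(=O)[C@H](O)c1ccccc1`: < 12 mL.min-1.g-1
compound 3 `CC(C)(C)[C@@H](O)C(=O)N1CC(=O)C[C@H]1C(=O)NCc1cc(Cl)ccc1-n1cnnn1`: < 12 mL.min-1.g-1

In an ADME assay on liver for metabolic stability, with Liver microsome (Homo sapiens) as the target, read by LC-MS, using microsomes (a lower number here means slower removal, a higher number faster removal of the compound), compound 1 gives < 12 mL.min-1.g-1, which is a limit of the assay and not a number. Compound 2 also gives < 12 mL.min-1.g-1 as a limit. Compound 3 likewise gives < 12 mL.min-1.g-1, again a limit. Going by the values given here, compound 1 therefore stands together with the others at the limit of < 12 mL.min-1.g-1 in this assay, at which 3 of the 3 values shown sit, and no step between the measured compounds can be sized. Compound 4 `CC(C)CC[C@@H](O)C(=O)N1N=CC[C@H]1C(=O)NCc1cc(Cl)ccc1-n1cnnn1` differs from compound 1 in one place: isopentyl in place of 1-methoxy-1-methylethyl on a saturated chain carbon bound to a carbonyl carbon and an oxygen on a saturated carbon. Among the compounds with values here, with no measured step to draw on, an estimated step of an at least 1.6-fold higher number from compound 1 to compound 4 (0.22 log units; that floor lies within the scatter) toward somewhat faster removal is expected, of a size that may just exceed the usual scatter. For compound 4 the expected value in this assay is 20 mL.min-1.g-1, within a range from 8 mL.min-1.g-1 to 50 mL.min-1.g-1.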

Compound 4, intrinsic clearance in microsomes: 47 mL.min-1.g-1
Estimate against measurement, compound 4: 2.4-fold (0.37 log units) below; low and high end bracket the measured number.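

In this assay compound 1 gives < 12 mL.min-1.g-1, which is a limit and not a number. Isopentyl in place of 1-methoxy-1-methylethyl brings an at least 3.9-fold higher number from compound 1 to compound 4 (0.59 log units; beyond the scatter), so the chain at this position can shift removal beyond the scatter. Compound 4 is the only compound shown clear of that limit: the limit of < 12 mL.min-1.g-1 in this assay, at which 3 of the 4 values shown sit.

Going by these compounds, the full size of the step stays open, as does whether the oxygen or the branching of the departing chain matters. On these data alone, how a cyclopropyl group or a longer chain containing a hydroxyl would read at this position also remains unknown.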